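The source may hold more compounds than are shown below. What is called first, only, known or untested is meant among the compounds shown, and "the series" means these compounds.

Compound 3 `CCOC(=O)CCCCCOc1cccc(CN(C(=O)c2ccc(-c3cccnc3)cc2)C(C)C)c1` carries an ethyl ester at the end of its side chain and a pyridin-3-yl group on the shared core. In an ADME assay on HEK293 cells (Homo sapiens) for cytotoxicity, read by CellTiter-Glo and resazurin assay, with a stated time of 72 h (a lower number here means that less compound is needed, a higher number that more compound is needed for the effect), compound 3 gives only a limit, > 26000 nM. Two related compounds were measured in the same way and also stop at a limit. Compound 1 `CCOc1cccc(-c2ccc(C(=O)N(Cc3cccc(OCCCCCC(=O)O)c3)C(C)C)cc2)c1` gives a limit of > 20800 nM in this assay. Compound 2 `COc1ccc(F)c(-c2ccc(C(=O)N(Cc3cccc(OCCCCCC(=O)O)c3)C(C)C)cc2)c1` gives a limit of > 26000 nM in this assay. Of the three values shown, one sits at the limit of > 20800 nM in this assay, at which 1 of the 3 values shown sits, and two at the limit of > 26000 nM in this assay, at which 2 of the 3 values shown sit, so no true number is available for any of them. Going by the values given here, the only step between measured compounds, a step that the two limits leave unreadable from compound 1 to compound 2, cannot be given a size for this reason.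

Compound 4 `CCOC(=O)CCCCCOc1cccc(CN(C(=O)c2ccc(-c3cc(F)cc(OC)c3)cc2)C(C)C)c1` differs from compound 3 in one place: 3-fluoro-5-methoxyphenyl in place of pyridin-3-yl on an aromatic carbon. No measured step bears on this change with a readable size, so there is nothing in the shown data that points to a shift in either direction. Compound 4 is therefore expected to give 30000 nM in this assay, with a range from 10000 nM to 100000 nM. The expected step that the limit leaves unreadable from compound 3 to compound 4 is none beyond the scatter, and the most likely outcome is that compound 4 again yields only a limit.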

Compound 4, half-maximal effective concentration: > 26000 nM
Compound 4: a limit, no number; the forecaster's own chance of this, stated with the estimate: 85%; the middle value lies beyond the limit too.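

Compound 3 and compound 4 both give only a limit in this assay, and the step between them cannot be read. The compounds shown leave open the concentration at which any of them would reach its half-maximal effect on these cells, and whether changing a single group alters that concentration at all.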